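Halogen position on the indazolyl group and cytotoxicity

The compounds below may be only part of what the source reports. "The series", "measured", "known", "first", "only" and "open" are said of these compounds alone.

Compound 2 `CC/C(=C(/c1ccc(/C=C/C(=O)O)cc1)c1cc2cn[nH]c2cc1F)c1ccccc1` gives 47 nM in a functional assay on MCF7 cells (Homo sapiens) for cytotoxicity, read by CellTiter-Glo, with a stated time of 5 days (on this read-out higher numbers stand for weaker inhibition and lower numbers for stronger inhibition), the highest of the two numbers shown; compound 1 `CC/C(=C(/c1ccc(/C=C/C(=O)O)cc1)c1ccc2[nH]nc(F)c2c1)c1ccccc1` gives 5 nM. Compound 3 `CC/C(=C(/c1ccc(/C=C/C(=O)O)cc1)c1cc(Cl)c2[nH]ncc2c1)c1ccccc1` carries 7-chloro-1H-indazol-5-yl in place of 6-fluoro-1H-indazol-5-yl on a double-bonded chain carbon bound to an aromatic carbon and a double-bonded chain carbon. Among the compounds with values here, the only measured step, a 9.4-fold higher number from compound 1 to compound 2 (0.97 log units; beyond the scatter), shows that moving the fluorine between the two measured variants shifted this assay by a margin beyond the scatter, so a further move of the halogen is likely to shift the read-out by a comparable amount, in a direction the data do not fix. For compound 3 the estimate is 15 nM (range 4 nM to 60 nM), an expected step of a 3.1-fold lower number from compound 2 to compound 3 (0.50 log units; beyond the scatter).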

Compound 3, half-maximal inhibitory concentration: 56 nM
The estimate for compound 3 lay 3.7-fold (0.57 log units) below the measured number; low and high end bracket the measured number.
By their numbers in this assay, from the lowest: compound 1; then compounds 2 and 3 (each within the scatter of the next).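

7-Chloro-1H-indazol-5-yl and 6-fluoro-1H-indazol-5-yl read alike at this place (a 1.2-fold higher number from compound 2 to compound 3 (0.08 log units; within the scatter)), so exchanging one for the other leaves the read-out within the scatter. Against 3-fluoro-1H-indazol-5-yl, the chloro variant gives a clearly weaker read-out (an 11-fold higher number from compound 1 to compound 3 (1.05 log units; beyond the scatter)), so only the 3-fluoro variant stands apart among the three. No available evidence bears on this result. Still open, from the compounds shown here alone, is whether a methyl group or a nitrile in place of the halogen on the indazolyl group would match compound 1 or stay with compounds 2 and 3.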